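Sulfonamide hydrazides: acyl in place of aryl on the hydrazide

This account rests on a few compounds, and the source may have more. Where it says the series, first, only, none or still open, it means among the compounds named here.

Compound 3 `Cc1cccc(NNC(=O)c2ccccc2NS(=O)(=O)c2cnc(O)nc2O)c1` stands only at a limit in a functional assay on A549 cells (Homo sapiens) for antiproliferative activity, read by MTT assay, with a stated time of 24 h; a lower number here means a stronger inhibitor, a higher number a weaker inhibitor: compound 3 gives > 20000 nM, a limit of the assay and not a number. Compound 1 `Cc1cccc(NNC(=O)c2ccc(NS(=O)(=O)c3cnc(O)nc3O)cc2)c1` likewise reports a limit, > 20000 nM in this assay. Compound 2 `O=C(NNc1ccc(F)cc1)c1cccc(NS(=O)(=O)c2cnc(O)nc2O)c1` also reports a limit, > 20000 nM in this assay. Going by the values given here, all measured values thus rest at the limit of > 20000 nM in this assay, at which 3 of the 3 values shown sit, so no step between measured compounds can be sized. Compound 4 `O=C(NNC(=O)c1ccccc1NS(=O)(=O)c1cnc(O)nc1O)c1cccc(Cl)c1` differs from compound 3 by (3-chlorophenyl)carbonyl in place of 3-methylphenyl on an amine nitrogen. With every measured member at the limit, the series gives no direction. The expected step is a step that the limit leaves unreadable from compound 3 to compound 4, none beyond the scatter. Compound 4 is estimated at 30000 nM, between 10000 nM and 100000 nM, and is expected most likely to return only a limit in this assay.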

Compound 4, half-maximal inhibitory concentration: 1260 nM
The estimate for compound 4 lay 24-fold (1.38 log units) above the measured number, and the stated range ends above it.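

In this assay, going by these compounds alone, this amine nitrogen is the first place to give a readable number: (3-chlorophenyl)carbonyl in place of 3-methylphenyl gives an at least 15-fold lower number from compound 3 to compound 4 (1.20 log units; beyond the scatter). The change adds a carbonyl and puts chlorine where methyl stood, so the step belongs to the whole change and not to either part. Its true size stays unread, since compound 3 gives only a limit: the limit of > 20000 nM in this assay, at which 3 of the 4 values shown sit.

Still open, on these data alone, is whether the carbonyl or the chlorine carries the step. Also open, as far as these compounds go, is how a (3-methylphenyl)carbonyl or a plain acetyl on this nitrogen would read.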